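The compounds below may be only part of what the source reports. "The series", "measured", "known", "first", "only" and "open" are said of these compounds alone.

Measured so far:
compound 1 `O=C1/C(=C\c2cc3ccccc3nc2Cl)c2ccccc2N1c1c(Cl)cccc1Cl` gives > 100 ug/mL in a functional assay on MCF7 cells (Homo sapiens) for cytotoxicity, read by MTT assay, with a stated time of 72 h (on this read-out lower numbers stand for an effect already at smaller amounts and higher numbers for an effect only at larger amounts of compound), a limit rather than a number.
compound 2 `Cc1ccc2nc(Cl)c(/C=C3\C(=O)N(c4c(Cl)cccc4Cl)c4ccccc43)cc2c1C` gives > 100 ug/mL in this assay, again only a limit.

Both results sit at the same edge of what the assay can report, namely (the limit of > 100 ug/mL in this assay, at which 2 of the 2 values shown sit). Within the data shown here, compound 2 therefore stands at no measured point on a scale; its result is a limit, and the one other value is a limit too. Compound 3 `Cc1ccc2nc(Cl)c(/C=C3\C(=O)N(c4c(Cl)cccc4Cl)c4ccccc43)cc2c1` differs from compound 2 in a single place: hydrogen in place of methyl on an aromatic carbon. Among the measured compounds shown here, no step between two measured compounds has been observed, so the size of such a change cannot be read from the data. Given that compound 2 sits at the limit of > 100 ug/mL in this assay, at which 2 of the 2 values shown sit, the step that the limit leaves unreadable from compound 2 to compound 3 is expected to be none beyond the scatter. In this assay compound 3 is estimated at 120 ug/mL, within 50 ug/mL to 300 ug/mL.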

Compound 3, concentration for half-maximal effect: > 100 ug/mL
Compound 3: only a limit was reported (the forecaster's own chance of this, stated with the estimate: 80%); the middle value is on the limit's open side.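

Among these compounds, no step among compound 1, compound 2 and compound 3 can be read, since all three results are limits rather than numbers: the limit of > 100 ug/mL in this assay, at which 3 of the 3 values shown sit. The compounds shown leave open whether hydrogen in place of methyl on an aromatic carbon changes cytotoxicity at all, and at what amount any of them would act.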